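From 3-nitrophenyl to 4-methoxyphenyl on a sulfonyl sulfur

The source may report more compounds than this note shows. Statements on the series, on what has been measured and on what is new or still open speak of the compounds shown alone.

Of the compounds shown here, three sharing one core have been tested in a functional assay on HepG2 cells (Homo sapiens) for antiproliferative activity, read by MTT assay, with a stated time of 48 h; a higher number here means a weaker inhibitor, a lower number a stronger inhibitor. Compound 1 `O=C(/C=C/c1cn(S(=O)(=O)c2ccc([N+](=O)[O-])cc2)c2ccccc12)c1ccncc1` gives 18300 nM, compound 2 `Cc1ccc(S(=O)(=O)n2cc(/C=C/C(=O)c3ccncc3)c3ccccc32)cc1` gives 44800 nM and compound 3 `O=C(/C=C/c1cn(S(=O)(=O)c2cccc([N+](=O)[O-])c2)c2ccccc12)c1ccncc1` gives 42600 nM. Compound 3 therefore sits level with compound 2, as the step of a 1.1-fold lower number from compound 2 to compound 3 (0.02 log units; within the scatter) shows, and both are weaker than compound 1.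

Compound 4 `COc1ccc(S(=O)(=O)n2cc(/C=C/C(=O)c3ccncc3)c3ccccc32)cc1` carries 4-methoxyphenyl in place of 3-nitrophenyl on a sulfonyl sulfur.

Among the measured compounds shown here, three measured steps bear on this change. Two are modest, a 2.4-fold higher number from compound 1 to compound 2 (0.39 log units; beyond the scatter) and a 2.3-fold higher number from compound 1 to compound 3 (0.37 log units; beyond the scatter), and both start from compound 1. The third, the swap of 4-methylphenyl for 3-nitrophenyl, is the closest parallel and produced no real change. Neither 4-methoxyphenyl nor its effect has been measured here, so this comparison is only a guide.

The expected result is a 1.1-fold lower number from compound 3 to compound 4 (0.05 log units; within the scatter), which would be no clear change. For compound 4 the estimated value is 38000 nM, with an expected range of 18000 nM to 75000 nM.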

Compound 4, half-maximal inhibitory concentration: 26000 nM
Beside the measured number, compound 4's estimate is 1.5-fold (0.16 log units) above it; the range from low to high includes it.
By their numbers in this assay, from the lowest: compounds 1, 4, 3 and 2 (each within the scatter of the next, the first and the last beyond it).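

In this assay, 4-methoxyphenyl on the sulfonyl sulfur cannot be told apart from any of the three earlier groups, since each step lies within the scatter (a 1.6-fold lower number from compound 3 to compound 4 (0.21 log units; within the scatter); a 1.7-fold lower number from compound 2 to compound 4 (0.24 log units; within the scatter); a 1.4-fold higher number from compound 1 to compound 4 (0.15 log units; within the scatter)). The earlier compounds shown here seemed to fall into two sets, with compound 1 on one side and compounds 2 and 3 on the other, but compound 4 now sits within the scatter of both sets, so that split looks less firm. Nothing available here bears on the reason for this result.

Going by these compounds, it remains open whether a phenyl ring carrying an amine or a carboxylic acid would give a clearly different number at this position. The same question applies to a longer alkyl chain on the sulfonyl sulfur in place of the ring.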